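Chloro for fluoro on the 2-fluorobenzyl group

The source may report more compounds than this note shows. Statements on the series, on what has been measured and on what is new or still open speak of the compounds shown alone.

Measured in an ADME assay on microsomes from liver (Homo sapiens) for metabolic stability, with a stated time of 60 min, tested at 1 uM; a lower number here means that less of the compound is left, a higher number that more of the compound is left
compound 1 `CS(=O)(=O)Nc1ccc2c(c1)S(=O)(=O)N=C(C1=C(O)[C@@H]3[C@H]4CC[C@H](C4)[C@@H]3N(Cc3ccccc3)C1=O)N2` gives 80%
compound 2 `CS(=O)(=O)Nc1ccc2c(c1)S(=O)(=O)N=C(C1=C(O)[C@@H]3[C@H]4CC[C@H](C4)[C@@H]3N(Cc3ccccc3F)C1=O)N2` gives 89%

Going by the values given here, compound 2 stands within the scatter of compound 1, the only other compound measured, so the two are not separated. Among the compounds with values here, the single measured step of a number 9 percentage points higher from compound 1 to compound 2 (within the scatter) is fluoro in place of hydrogen on an aromatic carbon. Compound 3 `CS(=O)(=O)Nc1ccc2c(c1)S(=O)(=O)N=C(C1=C(O)[C@@H]3[C@H]4CC[C@H](C4)[C@@H]3N(Cc3ccccc3Cl)C1=O)N2` has chloro in place of fluoro on an aromatic carbon, ortho to a large group chloro in place of fluoro on an aromatic carbon with the rest unchanged. Within the data shown here, no measured step covers this exchange directly, and the one available stays within the scatter, so no step beyond the scatter is expected in this assay for it. The estimated step is a number 6 percentage points lower from compound 2 to compound 3 (within the scatter) in this reading. Compound 3 is expected at 83% within 68% to 95% as the estimated range.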

Compound 3, percent of the compound remaining: 100%
Compound 3: the middle estimate sits 17 percentage points below what was measured, and the stated range ends below it.
By their numbers in this assay, from the lowest: compounds 1 and 2 (each within the scatter of the next); then compound 3.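

In this assay, going by these compounds alone, the exchange of fluoro for chloro on the benzyl group gives the first step at this position to lie beyond the scatter: a number 11 percentage points higher from compound 2 to compound 3 (beyond the scatter). Against the unsubstituted benzyl group, chloro also separates clearly, with a number 20 percentage points higher from compound 1 to compound 3 (beyond the scatter), whereas fluoro does not, with a number 9 percentage points higher from compound 1 to compound 2 (within the scatter). Nothing available explains the difference between the two halogens.

Open, from the compounds shown here alone, is how bromo, methyl or methoxy would read at this place. With compound 3 at 100%, this read-out leaves little room to show any further gain.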